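Swapping chloro for bromo in a weakly cytotoxic series

This account rests on a few compounds, and the source may have more. Where it says the series, first, only, none or still open, it means among the compounds named here.

Three compounds sharing one core were tested in a functional assay on PC-3 cells (Homo sapiens) for cytotoxicity, read by MTT assay, with a stated time of 72 h; on this read-out lower numbers stand for stronger inhibition and higher numbers for weaker inhibition. Compound 1 `O=C(Nc1ccc(Oc2ccnc3[nH]ccc23)c(F)c1)c1nn(-c2ccc(Br)cc2)ccc1=O` gives 40800 nM in this assay. Compound 2 `Cn1ccc2c(Oc3ccc(NC(=O)c4nn(-c5ccc(Br)cc5)ccc4=O)cc3)ccnc21` gives 23000 nM. Compound 3 `Cn1ccc2c(Oc3ccc(NC(=O)c4nn(-c5ccc(Cl)cc5)ccc4=O)cc3F)ccnc21` returns only a limit in this assay, > 60000 nM, so its true value is not known as a number. This is the limit of > 60000 nM in this assay, at which 1 of the 3 values shown sits; compound 3 therefore stands at the weak end of what has been measured, while compound 1 and compound 2 each gave a number.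

Compound 4 `Cn1ccc2c(Oc3ccc(NC(=O)c4nn(-c5ccc(Br)cc5)ccc4=O)cc3F)ccnc21` has not yet been measured. It differs from compound 3 by a single change: bromo in place of chloro on an aromatic carbon. Among the measured compounds shown here, no pair of measured compounds differing in only one place exists here, so the size of this step can only be expected, not read from the data. Compound 1, carrying bromo, gave 40800 nM, and compound 2, also carrying bromo, gave 23000 nM, numbers rather than a limit. In this assay the expected step is an at least 1.0-fold lower number from compound 3 to compound 4 (0.03 log units; that floor lies within the scatter), likely within the scatter. Compound 4 is expected to give about 55000 nM, with a range from 25000 nM to 120000 nM, and a fair chance that only a limit is reported again.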

Compound 4, half-maximal inhibitory concentration: > 60000 nM
Compound 4 was reported as a limit; the forecaster's own chance of this, stated with the estimate: 50%; middle value at least 1.0-fold (0.03 log units) from the limit.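

In this assay, the swap of chloro for bromo on the 4-chlorophenyl group cannot be sized, since compound 3 and compound 4 both end at a limit, not a number: the limit of > 60000 nM in this assay, at which 2 of the 4 values shown sit.

The other two comparisons can be read, at least in part. Fluoro in place of hydrogen on an aromatic carbon brings an at least 2.6-fold higher number from compound 2 to compound 4 (0.41 log units; beyond the scatter), so this bromo series does not hold a measurable value once that fluoro is present. Methyl in place of hydrogen on an aromatic nitrogen brings an at least 1.4-fold higher number from compound 1 to compound 4 (0.16 log units; that floor lies within the scatter), which leaves the size of that change undecided.

The compounds shown leave open whether chloro and bromo differ at all in this assay, and a pair that both give numbers would settle it. They also leave open whether an amine or a methoxy group at this position would bring a measurable value.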